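The source may hold more compounds than are shown below. What is called first, only, known or untested is meant among the compounds shown, and "the series" means these compounds.

Of the compounds shown here, three have so far been measured in a functional assay on A2780 cells (Homo sapiens) for inhibition, with a stated time of 72 h, tested at 10 uM; a lower number here means less inhibition of growth, a higher number more inhibition of growth at the concentration tested. Compound 1 `CC1(C)CCOc2ccc(NC(=S)Nc3ccc(OC(F)(F)F)cc3)cc21` gives 16%. Compound 2 `CC1(C)CC(C)(C)c2cc(NC(=O)Nc3ccc(C(F)(F)F)cc3)ccc2O1` gives 88.4%. Compound 3 `CCC1(CC)CC(CC)(CC)c2cc(NC(=O)Nc3ccc(OC(F)(F)F)cc3)ccc2O1` gives 67%, the second highest of the three numbers: its nearest neighbour is compound 2, whose number lies higher by a gap beyond the usual scatter, and its furthest is compound 1, whose number lies lower by a gap that is also beyond that scatter. Compound 4 `CCC1(CC)CC(CC)(CC)c2cc(NC(=O)Nc3ccc(C(F)(F)F)cc3)ccc2O1` has not yet been measured. It differs from compound 3 in one place: trifluoromethyl in place of trifluoromethoxy on an aromatic carbon. Among the measured compounds shown here, no pair of measured compounds differs only in this way, so the size of this step cannot be read off directly. Compound 2 carries trifluoromethyl, as compound 4 does, and stands highest, while compound 1 carries trifluoromethoxy and stands lowest, but each of them also differs from compound 3 in its core or linker. A modest rise, or none beyond the scatter, is therefore expected in this assay. Compound 4 is expected to show a step of a number 8 percentage points higher from compound 3 to compound 4 (within the scatter). Compound 4 is estimated at 75%, with a range from 55% to 92%.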

Compound 4, percent growth inhibition at one concentration: 86.2%
For compound 4 the middle estimate is 11.2 percentage points below the measured one; the range from low to high includes it.
By their numbers in this assay, from the lowest: compound 1; then compound 3; then compounds 4 and 2 (each within the scatter of the next).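

Within this assay, the change from 4-(trifluoromethoxy)phenyl to 4-(trifluoromethyl)phenyl gives a number 19.2 percentage points higher from compound 3 to compound 4 (beyond the scatter) with nothing else altered, so this change now has a size of its own. The place on an aromatic carbon, para to a large group, is therefore not indifferent to which of these two groups it carries on this core, something compounds 1 and 2 could not show, since each also differs from compound 3 in its core or linker. No measurement shown here accounts for the step.

Going by these compounds, whether the same change gives a similar step on the core of compound 1 or of compound 2 remains open. So does how other groups at this place, such as a nitrile, a methoxy group or an amine, would compare with these two.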